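Sulfonyl benzylamides: swapping the bicyclic amide headgroup

The compounds below may be only part of what the source reports. "The series", "measured", "known", "first", "only" and "open" are said of these compounds alone.

Measured compounds:
compound 1 `O=C(NCc1ccc(S(=O)(=O)c2ccccc2)cc1)c1cn2ccnc2cn1`: 150 nM
compound 2 `O=C(NCc1ccc(S(=O)(=O)c2cccc(C(F)(F)F)c2)cc1)c1ccc2nccn2c1`: 8 nM
compound 3 `O=C(NCc1ccc(S(=O)(=O)c2cc(F)cc(F)c2)cc1)c1cc2ccncc2o1`: 14 nM

In an assay for inhibition of Nicotinamide phosphoribosyltransferase (Homo sapiens), read by mass spectrometry, with stated times of 15 min and 30 min (a higher number here means a weaker inhibitor, a lower number a stronger inhibitor), compound 1 stands at the highest of the three numbers; compound 3 sits well beyond the scatter below it, and compound 2 further still. Among the measured compounds shown here, compounds 2 and 3 differ from compound 1 in both the headgroup and the sulfonyl aryl, so no single step within the measured set can be isolated.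

Compound 4 `O=C(NCc1ccc(S(=O)(=O)c2ccccc2)cc1)c1cnc2nccn2c1` is an isomer of compound 1: a group of 9 heavy atoms (6 carbon, 3 nitrogen; one five-membered aromatic ring with 2 hetero atoms, one six-membered aromatic ring with 2 hetero atoms) in place of a group of 9 heavy atoms (6 carbon, 3 nitrogen; one five-membered aromatic ring with 2 hetero atoms, one six-membered aromatic ring with 2 hetero atoms), on a carbonyl carbon. For the measured compounds named here, with no measured pair of this kind, the expectation for this assay is a step within the scatter, direction uncertain. Compound 4 is estimated at 110 nM (range 35 nM to 350 nM), which would be a step of a 1.4-fold lower number from compound 1 to compound 4 (0.13 log units; within the scatter).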

Compound 4, half-maximal inhibitory concentration: 2 nM
Estimate against measurement, compound 4: 55-fold (1.74 log units) above; the whole stated range lies above it.
By their numbers in this assay, from the lowest: compound 4; then compounds 2 and 3 (each within the scatter of the next); then compound 1.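

With the rest of the molecule held constant, the headgroup change alone gives a 75-fold lower number from compound 1 to compound 4 (1.88 log units; beyond the scatter) in this assay. Rearranging the same atoms on the carbonyl carbon therefore matters strongly here, although the counts of rings, heavy atoms and hydrogen-bond acceptors stay the same. Compound 2 and compound 3 could not isolate this, since each also differs in the sulfonyl aryl, and nothing measured here accounts for the size of the step. On these data alone, whether the gain carries over to substituted sulfonyl aryl groups remains open. So does the effect of an amine or a carboxylic acid on the headgroup.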